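Swapping a Thioester Tail for an Oxazole Ring

The compounds below may be only part of what the source reports. "The series", "measured", "known", "first", "only" and "open" are said of these compounds alone.

Measured so far:
- compound 1, `CC1=C(C(=O)C2CC2)C(c2ccoc2)NC(=O)N1`: 16%
- compound 2, `CCSC(=O)C1=C(C)NC(=O)NC1c1ccoc1`: 1%

In an assay on membranes from HeLa cells for displacement of a labelled ligand from adenosine receptor A3 (Homo sapiens), read by scintillation counting, with a stated time of 180 min, tested at 1 uM (on this read-out higher numbers stand for more inhibition at the one concentration tested (going by the name of the read-out) and lower numbers for less inhibition), compound 2 gives 1%, the lowest of the two numbers seen; its nearest neighbour is compound 1, which gives 16%. Among the measured compounds shown here, the only measured step, a number 15 percentage points lower from compound 1 to compound 2 (beyond the scatter), came from putting ethylsulfanyl in place of cyclopropyl on a carbonyl carbon. Compound 3, `CC1=C(c2ncc(C)o2)C(c2ccoc2)NC(=O)N1`, is not yet measured. Its difference from compound 2 is 5-methyl-1,3-oxazol-2-yl in place of (ethylsulfanyl)carbonyl on a double-bonded ring carbon. For the measured compounds named here, no measured step involves a 5-methyl-1,3-oxazol-2-yl group, so the single step known bears only loosely on this change: it shows that the group on this double-bonded ring carbon can move the read-out by a modest amount. Since compound 2 sits near the bottom of the scale, a step upward is more likely than one downward, but only a small one is expected from compound 2 to compound 3, a number 9 percentage points higher from compound 2 to compound 3 (within the scatter). For compound 3 the estimate is 10%, with a range from 0% to 30%.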

Compound 3, a percentage reported as inhibition, at one concentration (the size of the read-out at that concentration, not a potency): 1%
Estimate against measurement, compound 3: 9 percentage points above; the range from low to high includes it.
By their numbers in this assay, from the lowest: compounds 2 and 3 (each within the scatter of the next); then compound 1.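

In this assay, putting 5-methyl-1,3-oxazol-2-yl in place of (ethylsulfanyl)carbonyl gives no change at the digits printed from compound 2 to compound 3 (within the scatter), so at this position an aromatic ring reads the same as the chain without a ring. Measured against cyclopropylcarbonyl, the same ring gives a number 15 percentage points lower from compound 1 to compound 3 (beyond the scatter), which means that two quite different groups now both fall short of the cyclopropylcarbonyl of compound 1. Nothing available explains why these groups read as they do.

On these data alone, it remains open whether any group on this double-bonded ring carbon can rise above compound 1, such as a carboxylic acid, an amine or a longer ketone chain. With so few groups compared, it is also unclear whether cyclopropylcarbonyl stands out for its small ring or for its carbonyl, which a plain acetyl group could help separate.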